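Trifluoromethoxy in place of cyano on a weak series

This account rests on a few compounds, and the source may have more. Where it says the series, first, only, none or still open, it means among the compounds named here.

Measured compounds:
compound 1, `Cc1n[nH]c(C(=O)O)c1Cc1cccc(-c2ccc(C#N)cc2)c1`, 13%
compound 2, `Cc1n[nH]c(C(=O)O)c1Cc1cccc(-c2ccccc2F)c1`, 5%
compound 3, `Cc1n[nH]c(C(=O)O)c1Cc1cccc(C(=O)O)c1`, 3%

Three compounds share one core and differ only in the group attached to the outer aromatic ring. For the measured compounds named here, in an assay on isolated protein for inhibition of 2-Hydroxyacid oxidase 2 (Homo sapiens), tested at 1 uM (on this read-out lower numbers stand for a weaker effect and higher numbers for a stronger effect at the one concentration tested), compound 1 gives 13%, the highest of the three numbers, but its steps to the others are small: a number 8 percentage points lower from compound 1 to compound 2 (within the scatter) and a number 10 percentage points lower from compound 1 to compound 3 (within the scatter), both within the scatter of this assay, so no compound can be called stronger or weaker than another on these data. The step of a number 2 percentage points lower from compound 2 to compound 3 (within the scatter) is within the scatter as well. Going by the values given here, in short, every exchange at this position so far, whether to another aromatic ring or to a carboxy group, has left the read-out near the bottom of the scale.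

Compound 4, `Cc1n[nH]c(C(=O)O)c1Cc1cccc(-c2ccc(OC(F)(F)F)cc2)c1`, is the next member. It differs from compound 1 as follows: trifluoromethoxy in place of cyano on an aromatic carbon. Among the compounds with values here, compound 1 is the only compound that carries a group in this place of the outer ring, so no measured step tells exactly what a change there does; the three steps that exist all replaced the whole ring and all stayed within the scatter. The expectation is therefore that the step of a number 1 percentage points lower from compound 1 to compound 4 (within the scatter) stays within the scatter, in no particular direction. Compound 4 is thus estimated at 12%, with a range from 0% to 30%.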

Compound 4, a percentage reported as inhibition, at one concentration (the size of the read-out at that concentration, not a potency): 6%
Compound 4: middle estimate off by 6 percentage points, on the high side, and the stated range covers the measured number.
By their numbers in this assay, from the lowest: compounds 3, 2, 4 and 1 (each within the scatter of the next).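

Among these compounds, this is the only exchange in this assay that keeps the outer ring and changes just the group on it, on an aromatic carbon para to a large group. Trifluoromethoxy in place of cyano gives a number 7 percentage points lower from compound 1 to compound 4 (within the scatter) and so cannot be told apart from no change at all. The earlier steps shown here replaced the whole ring, whereas this one shows that a swap confined to the group on that ring also leaves the read-out near the bottom of the scale, so compound 4 adds a second substituted ring to the series without adding any sign of a stronger effect. No measurement shown here speaks to what lies behind this result.

Still open, from the compounds shown here alone, is whether a different kind of group at this place, such as an amine, a primary amide or a longer carbon chain, could lift the read-out clear of the scatter. These numbers come from one tested concentration and give no potency, so they also leave open whether any of the four compounds would show a clear effect at a higher concentration.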